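This account rests on a few compounds, and the source may have more. Where it says the series, first, only, none or still open, it means among the compounds named here.

Measured compounds:
Compound 1 `COc1cc(-c2nn(-c3cccc(NC(=O)Nc4cc(C(F)(F)F)cc(C(F)(F)F)c4)c3)cc2-c2ccncc2)ccc1Cl` gives 661 nM.
Compound 2 `O=C(Nc1cccc(-n2cc(-c3ccncc3)c(-c3ccc(Cl)c(O)c3)n2)c1)Nc1ccc(Cl)c(Cl)c1` gives 1110 nM.

Both numbers come from a functional assay on UACC-62 cells (Homo sapiens) for inhibition, read by sulforhodamine B assay, with a stated time of 48 h; a lower number here means a stronger inhibitor of growth, a higher number a weaker inhibitor of growth. Compound 1 has the lowest of the two numbers; its nearest neighbour is compound 2, whose number is higher, but the gap between compound 1 and compound 2 lies within the scatter, so the two cannot be ordered. Among the compounds with values here, no single-change step between measured compounds is available.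

The unmeasured compound 3 `COc1cc(-c2nn(-c3cccc(NC(=O)Nc4cccc(C(F)(F)F)c4)c3)cc2-c2ccncc2)ccc1Cl` differs from compound 1 in one place: hydrogen in place of trifluoromethyl on an aromatic carbon. Within the data shown here, with no measured step to lean on, the direction and size of the change can only be expected. One of two trifluoromethyl groups is lost, and a step towards a somewhat higher number is expected, though it may well stay within the scatter. Compound 3 is therefore expected to give 1200 nM in this assay, with a range from 500 nM to 3000 nM, which amounts to an expected step of a 1.8-fold higher number from compound 1 to compound 3 (0.26 log units; within the scatter).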

Compound 3, concentration for 50% growth inhibition: 725 nM
Beside the measured number, compound 3's estimate is 1.7-fold (0.22 log units) above it; measured number inside the range.
By their numbers in this assay, from the lowest: compounds 1, 3 and 2 (each within the scatter of the next).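

In this assay, within the data shown here, the only single-change step in the set is a 1.1-fold higher number from compound 1 to compound 3 (0.04 log units; within the scatter), so hydrogen in place of trifluoromethyl at this position makes no readable difference. The position, on an aromatic carbon and meta to a trifluoromethyl group, therefore tolerates the loss of this one group in the core of compound 1, as long as the other trifluoromethyl group remains. Nothing measured here explains this result.

The compounds shown leave open whether the remaining trifluoromethyl group can also give way to hydrogen, since this one step says nothing about a ring with neither group. They also leave open whether a group of another kind at this position, such as an amine, a carboxylic acid or a longer alkyl chain, would give a number readably different from that of compound 1.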